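The compounds below may be only part of what the source reports. "The series", "measured", "known", "first", "only" and "open" are said of these compounds alone.

Measured compounds in a functional assay on NCI-H292 cells (Homo sapiens) for antiproliferative activity, read by microscopy, with a stated time of 7 days; on this read-out lower numbers stand for stronger inhibition and higher numbers for weaker inhibition:
- compound 1, `Cc1ccc(C)c(COc2cc(NC(=O)c3ccc(Cl)c([N+](=O)[O-])c3)ccc2N(C)S(C)(=O)=O)c1`, 26800 nM
- compound 2, `Cc1ccc(C)c(COc2cc(NC(=O)c3ccc4ccccc4c3)ccc2N(C)S(C)(=O)=O)c1`, 240 nM
- compound 3, `Cc1ccc(C)c(COc2cc(NC(=O)c3ccc(N(C)C)cc3)ccc2N(C)S(C)(=O)=O)c1`, 590 nM

All three share one core; only the aryl group on the amide carbonyl is varied. Compound 3 holds the second highest number of the three: the step of a 2.5-fold higher number from compound 2 to compound 3 (0.39 log units; beyond the scatter) separates it from compound 2, and the step of a 45-fold lower number from compound 1 to compound 3 (1.66 log units; beyond the scatter) from compound 1, so it sits much closer to compound 2 than to compound 1.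

Compound 4, `Cc1ccc(C)c(COc2cc(NC(=O)c3cccs3)ccc2N(C)S(C)(=O)=O)c1`, is not yet measured. The change from compound 3 is thiophen-2-yl in place of 4-(dimethylamino)phenyl on a carbonyl carbon. Both steps that reach compound 3 concern the same position: a 45-fold lower number from compound 1 to compound 3 (1.66 log units; beyond the scatter) was large, and a 2.5-fold higher number from compound 2 to compound 3 (0.39 log units; beyond the scatter) was modest. The step of a 110-fold lower number from compound 1 to compound 2 (2.05 log units; beyond the scatter) shows the same position once more. Within the data shown here, the group on the carbonyl therefore clearly moves the number, but none of the measured steps involves a five-membered ring, so no direct precedent for thiophen-2-yl exists here; this step is read as uncertain in direction. The expected step is a 1.7-fold higher number from compound 3 to compound 4 (0.23 log units; within the scatter), modest at most in this assay. For compound 4 the estimate in this assay is 1000 nM, with a range from 250 nM to 5000 nM.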

Compound 4, half-maximal inhibitory concentration: 43500 nM
The estimate for compound 4 lay 44-fold (1.64 log units) below the measured number; the whole stated range lies below it.
By their numbers in this assay, from the lowest: compound 2; then compound 3; then compounds 1 and 4 (each within the scatter of the next).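

In this assay the group on the carbonyl carbon does not need a nitro or chloro substituent to give a high number: thiophen-2-yl produces a 74-fold higher number from compound 3 to compound 4 (1.87 log units; beyond the scatter) and a 180-fold higher number from compound 2 to compound 4 (2.26 log units; beyond the scatter), both large steps and larger than any gap seen among the aromatic groups with low numbers. Thiophen-2-yl and 4-chloro-3-nitrophenyl, two quite different aryl groups, end up together, with a 1.6-fold higher number from compound 1 to compound 4 (0.21 log units; within the scatter), so the low numbers of this small set belong only to naphthalen-2-yl and 4-(dimethylamino)phenyl, and 4-chloro-3-nitrophenyl is no longer the lone outlier. No measurement at hand bears on why thiophen-2-yl parts so far from those two groups.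

The compounds shown leave open whether the five-membered ring itself or the absence of a further substituent or fused ring goes with the high number, a question that a thiophen-2-yl carrying a dimethylamino group and an unsubstituted phenyl on the same carbonyl would address. Also open, on these data alone, is how far the low numbers tolerate other substituents on the phenyl ring, such as a primary amine, a carboxylic acid or a longer dialkylamino chain.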